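The source may hold more compounds than are shown below. What is called first, only, known or untested is meant among the compounds shown, and "the series" means these compounds.

Measured compounds:
- compound 1, `CNS(=O)(=O)c1cc(C(=O)O)ccc1NCCC(C)(C)C`: 2.6%
- compound 2, `CCCCNc1ccc(C(=O)O)cc1S(=O)(=O)N(C)C`: 15.6%
- compound 3, `CN(C)S(=O)(=O)c1cc(C(=O)O)ccc1NCCCC(F)(F)F`: 1.9%

In an assay on HEK293 cells for inhibition of solute carrier family 12 member 2 (Homo sapiens), read by fluorescence, with a stated time of 30 min, tested at 100 uM (on this read-out higher numbers stand for a stronger effect at the one concentration tested and lower numbers for a weaker effect), compound 3 stands lowest of the three numbers. Its nearest neighbour is compound 1, which lies within the scatter of it, so the two cannot be told apart; the furthest is compound 2, which lies beyond the scatter above it. For the measured compounds named here, only one single-point step has been measured: a number 13.7 percentage points lower from compound 2 to compound 3 (beyond the scatter). That step put a trifluoromethyl in place of a methyl on the chain that hangs from the aromatic nitrogen, and the read-out fell by a modest amount.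

Compound 4, `COCCNc1ccc(C(=O)O)cc1S(=O)(=O)N(C)C`, has not yet been measured. It differs from compound 3 in one place: methoxy in place of 2,2,2-trifluoroethyl on a saturated chain carbon, two bonds along the chain from a nitrogen on an aromatic ring. Going by the values given here, no measured step covers this exact exchange. Among the compounds with values here, the one step that touches the same chain, the step from compound 2 to compound 3, removed a methyl in favour of a fluorinated group and lowered the number; compound 4 removes the fluorinated group again, but replaces it with a methoxy, which is not the methyl of compound 2. The expectation is therefore for no step beyond the scatter, or at most a small rise, a number 5.1 percentage points higher from compound 3 to compound 4 (within the scatter). Compound 4 is estimated to give 7% in this assay, within the range 0% to 20%.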

Compound 4, a percentage reported as inhibition, at one concentration (the size of the read-out at that concentration, not a potency): 4.1%
For compound 4 the middle estimate is 2.9 percentage points above the measured one; low and high end bracket the measured number.
By their numbers in this assay, from the lowest: compounds 3, 1 and 4 (each within the scatter of the next); then compound 2.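

In this assay, putting methoxy in place of 2,2,2-trifluoroethyl on a saturated chain carbon, two bonds along the chain from a nitrogen on an aromatic ring, gives a number 2.2 percentage points higher from compound 3 to compound 4 (within the scatter), so these two groups cannot be told apart at this position. Putting methoxy in place of ethyl at that same position gives a number 11.5 percentage points lower from compound 2 to compound 4 (beyond the scatter), which shows that a fall from compound 2 does not require fluorine, since a chain end with oxygen and no fluorine also gives a lower number. Nothing measured here explains why the plain butyl chain of compound 2 stands above both of these replacements.

The compounds shown leave open whether a longer plain chain, or a chain ending in an amine or a hydroxyl group, in place of the 2-methoxyethyl would keep the number low or raise it. Compound 2 reaches only 15.6% at the one concentration tested, so how strong or weak the effect of any of these compounds would be at other concentrations also remains open.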